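Extending the 4-methylphenyl arm of compound 2

The source may report more compounds than this note shows. Statements on the series, on what has been measured and on what is new or still open speak of the compounds shown alone.

The compounds share one core bearing a sulfonamide and a variable aromatic arm. Compound 1 `COc1ncc(-c2ccc3nccc(N4CCCC4)c3c2)cc1NS(=O)(=O)c1ccc(F)cc1F` carries pyrrolidin-1-yl on that position; in a functional assay on A549 cells (Homo sapiens) for cytotoxicity, read by MTT assay, with a stated time of 72 h (on this read-out lower numbers stand for stronger inhibition and higher numbers for weaker inhibition), compound 1 gives 3410 nM. Within the data shown here, compound 2 `COc1ncc(-c2ccc3nccc(-c4ccc(C)cc4)c3c2)cc1NS(=O)(=O)c1ccc(F)cc1F` replaces it with 4-methylphenyl and in this assay compound 2 gives 1240 nM, the lowest of the two numbers so far, the difference being a 2.8-fold lower number from compound 1 to compound 2 (0.44 log units; beyond the scatter).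

Compound 3 `CCN(CC)Cc1ccc(-c2ccnc3ccc(-c4cnc(OC)c(NS(=O)(=O)c5ccc(F)cc5F)c4)cc23)cc1` differs from compound 2 by diethylamino in place of hydrogen on a saturated chain carbon bound to an aromatic carbon; the same difference read one bond further out is methyl to (diethylamino)methyl, or 4-methylphenyl to 4-((diethylamino)methyl)phenyl. Among the measured compounds shown here, no measured step touches this kind of change, since the only known step exchanges the whole arm rather than extending it. A small move downward is therefore expected for compound 3, with a wide range, giving a 1.8-fold lower number from compound 2 to compound 3 (0.25 log units; within the scatter). Compound 3 is estimated at 700 nM in this assay, between 250 nM and 2500 nM.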

Compound 3, half-maximal inhibitory concentration: 22 nM
The estimate for compound 3 lay 32-fold (1.50 log units) above the measured number, and the stated range ends above it.
By their numbers in this assay, from the lowest: compound 3; then compound 2; then compound 1.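

In this assay, extending the arm counts for far more than the earlier exchange of one whole arm for another: diethylamino in place of hydrogen on a saturated chain carbon bound to an aromatic carbon gives a 56-fold lower number from compound 2 to compound 3 (1.75 log units; beyond the scatter), a large step beside the modest 2.8-fold lower number from compound 1 to compound 2 (0.44 log units; beyond the scatter). Set against the pyrrolidin-1-yl arm, the 4-((diethylamino)methyl)phenyl arm gives a 160-fold lower number from compound 1 to compound 3 (2.19 log units; beyond the scatter), which puts compound 3 lowest of the three, with both of its steps beyond the scatter. Nothing available accounts for why this one addition has so large an effect.

The compounds shown leave open whether the step depends on diethylamino itself or would also follow from another amine on that carbon, such as morpholine or piperidine. They also leave open how a carboxylic acid there, or a longer chain carrying the diethylamino, would read.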